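Swapping a Chain Carbon for Oxygen in the Side Chain

The source may hold more compounds than are shown below. What is called first, only, known or untested is meant among the compounds shown, and "the series" means these compounds.

Going by the values given here, compound 2 `CN1CCC(c2ccc3c(c2)oc(=O)n3C(=O)NCCCCc2ccccc2)CC1` is the stronger of the two compounds measured so far in an assay on HEK293 cells for inhibition of acid ceramidase (Homo sapiens), read by fluorescence, with stated times of 10 min and 3 h (a lower number here means a stronger inhibitor, a higher number a weaker inhibitor), where compound 2 gives 129 nM. Among the compounds with values here, its only measured neighbour is compound 1 `CCC(C)NC(=O)n1c(=O)oc2cc(C3CCN(C)CC3)ccc21`, which in this assay gives 2100 nM. The two differ only in the group on the amide-type nitrogen, and the step of a 16-fold lower number from compound 1 to compound 2 (1.21 log units; beyond the scatter) shows that the longer chain ending in an aromatic ring suits this assay far better than the short branched one.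

Compound 3 `CN1CCC(c2ccc3c(c2)oc(=O)n3C(=O)NCCOCc2ccccc2)CC1` keeps the chain length and the aromatic ring of compound 2 but alters one link: benzyloxy in place of phenethyl on a saturated chain carbon, two bonds along the chain from an amide-type nitrogen. Within the data shown here, the single measured step speaks for the chain that ends in an aromatic ring, and that feature is retained; the new element is the oxygen within the chain, and nothing measured here tells how such an oxygen is received. Compound 3 is therefore expected to give about 220 nM, between 80 nM and 650 nM. The step of a 1.7-fold higher number from compound 2 to compound 3 (0.23 log units; within the scatter) is expected to stay small, leaning if anything toward a weaker inhibitor.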

Compound 3, half-maximal inhibitory concentration: 215 nM
Beside the measured number, compound 3's estimate is 1.0-fold (0.01 log units) above it; the measured number falls inside the stated range.
By their numbers in this assay, from the lowest: compounds 2 and 3 (each within the scatter of the next); then compound 1.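

The oxygen is the new information here: benzyloxy carries 1 hydrogen-bond acceptor where phenethyl carries 0, yet on this saturated chain carbon, two bonds along the chain from an amide-type nitrogen, the swap gives a 1.7-fold higher number from compound 2 to compound 3 (0.22 log units; within the scatter) in this assay. So, in this one pair, a chain carbon can be exchanged for an oxygen with no change that this assay can separate from the ordinary spread of repeat measurements. The advantage over the short branched group also survives the exchange, as 2-(benzyloxy)ethyl in place of sec-butyl gives a 9.8-fold lower number from compound 1 to compound 3 (0.99 log units; beyond the scatter), so that advantage does not depend on an all-carbon chain in these compounds.

No supporting measurement is available to explain how the oxygen is accommodated. The compounds shown leave open whether an amine nitrogen or a sulfur atom in the same link of the chain would be received as the oxygen is, and whether a longer chain carrying the oxygen and ending in the same aromatic ring would keep this level of inhibition.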